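Working notes: replacing naphthalen-2-yl on the chain carbon

This account rests on a few compounds, and the source may have more. Where it says the series, first, only, none or still open, it means among the compounds named here.

In an in vivo ADME assay on the whole organism (Cavia porcellus) (on this read-out higher numbers stand for a longer-lived compound and lower numbers for a shorter-lived compound), compound 1 `CC(NC(=O)c1ccc(C(=N)N)cc1)C(C)(C)C(=O)N1CCC(CC(=O)O)CC1` gives 0.883 h and compound 2 `CCCC(NC(=O)c1ccc(C(=N)N)cc1)C(C)(C)C(=O)N1CCC(CC(=O)O)CC1` gives 0.9 h while compound 3 `CC(C)(C(=O)N1CCC(CC(=O)O)CC1)C(NC(=O)c1ccc(C(=N)N)cc1)c1ccc2ccccc2c1` gives 0.85 h and so stands level with both within the scatter. The change to compound 4 `CC(C)(C(=O)N1CCC(CC(=O)O)CC1)C(NC(=O)c1ccc(C(=N)N)cc1)c1cccc(O)c1` reads 3-hydroxyphenyl in place of naphthalen-2-yl on a saturated chain carbon bound to an amide-type nitrogen and a saturated chain carbon and puts 3-hydroxyphenyl in place of naphthalen-2-yl on a saturated chain carbon bound to an amide-type nitrogen and a saturated chain carbon. Two measured steps at this carbon bear on it, a 1.0-fold lower number from compound 1 to compound 3 (0.02 log units; within the scatter) and a 1.1-fold lower number from compound 2 to compound 3 (0.02 log units; within the scatter) and both lie within the scatter. Within the data shown here, no measured compound carries 3-hydroxyphenyl. The expected step is no change at the digits printed from compound 3 to compound 4 (within the scatter) and so none beyond the scatter. In this assay compound 4 is estimated at 0.85 h with 0.5 h to 1.4 h as the expected range.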

Compound 4, half-life: 1.08 h
Compound 4: the middle estimate sits 1.3-fold (0.10 log units) below what was measured, within the range that was stated.
By their numbers in this assay, from the lowest: compounds 3, 1, 2 and 4 (each within the scatter of the next).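

In this assay 3-hydroxyphenyl on this chain carbon stands level with naphthalen-2-yl, with a 1.3-fold higher number from compound 3 to compound 4 (0.10 log units; within the scatter), with propyl, with a 1.2-fold higher number from compound 2 to compound 4 (0.08 log units; within the scatter), and with methyl, with a 1.2-fold higher number from compound 1 to compound 4 (0.09 log units; within the scatter). Among these compounds, the earlier groups were hydrocarbon only, so this is the first group at this carbon to bring a hydrogen-bond donor and acceptor, and no step beyond the scatter comes with it. No supporting data bear on these steps. Going by these compounds, whether an amine or a carboxylic acid on this carbon would also stay within the scatter remains open.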